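Varying the aryl on the carbonyl in the shared core

The source may report more compounds than this note shows. Statements on the series, on what has been measured and on what is new or still open speak of the compounds shown alone.

Three measured compounds share one core and differ only in the aryl on the carbonyl carbon. Compound 1 `O=C(Nc1cc(-c2ccccc2)nn1-c1ccccc1)c1cccc(C(F)(F)F)c1` gives 228 nM in a functional assay on cells for positive allosteric modulation of metabotropic glutamate receptor 5 (Rattus norvegicus), read by calcium flux; on this read-out higher numbers stand for an effect only at larger amounts of compound and lower numbers for an effect already at smaller amounts. Compound 2 `COc1ccc(C(=O)Nc2cc(-c3ccccc3)nn2-c2ccccc2)cc1` gives 54 nM in this assay, and compound 3 `O=C(Nc1cc(-c2ccccc2)nn1-c1ccccc1)c1ccc(OC(F)(F)F)cc1` gives 18 nM in this assay. The two steps are a 4.2-fold lower number from compound 1 to compound 2 (0.63 log units; beyond the scatter) and a 3.0-fold lower number from compound 2 to compound 3 (0.48 log units; beyond the scatter). Compound 2 therefore stands second highest of the three numbers, between compound 1 above and compound 3 below.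

Compound 4 `COc1cc(OC)cc(C(=O)Nc2cc(-c3ccccc3)nn2-c2ccccc2)c1` is not yet measured. The change from compound 2 is 3,5-dimethoxyphenyl in place of 4-methoxyphenyl on a carbonyl carbon. The step from compound 1 to compound 2 shows that exchanging the aryl on the carbonyl moves the number modestly; the step from compound 2 to compound 3 alters only the group on the oxygen and keeps a single methoxy. Neither step tests a second methoxy, so a modest step in either direction, or none beyond the scatter, is expected in this assay. Compound 4 is estimated at 110 nM, with a range of 30 nM to 450 nM, that is a 2.0-fold higher number from compound 2 to compound 4 (0.31 log units; beyond the scatter).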

Compound 4, half-maximal effective concentration: 2040 nM
Compound 4: the middle estimate sits 19-fold (1.27 log units) below what was measured; the whole stated range lies below it.
By their numbers in this assay, from the lowest: compound 3; then compound 2; then compound 1; then compound 4.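

Among these compounds, exchanging 4-methoxyphenyl for 3,5-dimethoxyphenyl on the carbonyl carbon gives a 38-fold higher number from compound 2 to compound 4 (1.58 log units; beyond the scatter) in this assay, so this position can produce a large step, not only the modest ones seen among the earlier compounds. The same aryl also compares unfavourably with 3-(trifluoromethyl)phenyl, the aryl of the previous highest number, with an 8.9-fold higher number from compound 1 to compound 4 (0.95 log units; beyond the scatter), and compound 4 now has the highest number of the four. Nothing available on these compounds accounts for the size of this step.

The change adds a second methoxy and also replaces the 4-methoxy arrangement, and these two parts cannot be separated here; 3-methoxyphenyl would read the effect of the methoxy placement on its own. From the compounds shown here alone, whether an aryl bearing an amine or a carboxylic acid is tolerated on the carbonyl carbon also remains open.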